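Working notes: from compound 2 to compound 4

The compounds below may be only part of what the source reports. "The series", "measured", "known", "first", "only" and "open" are said of these compounds alone.

Values in a functional assay on L1210 cells (Mus musculus) for inhibition, read by MTT assay, with a stated time of 72 h; on this read-out higher numbers stand for weaker inhibition and lower numbers for stronger inhibition:
- compound 1 `COc1cc(NC(C)CCCNC(=O)Nc2cccc(F)c2)c2ncccc2c1`: 19000 nM
- compound 2 `COc1cc(NC(C)CCCNC(=O)Nc2ccc(Br)cc2)c2ncccc2c1`: 18000 nM
- compound 3 `COc1cc(NC(C)CCCNC(=O)NNC(=O)Nc2cccc(F)c2)c2ncccc2c1`: 108000 nM

Compound 2 shares the low end of these three numbers with compound 1, while compound 3 stands apart. The next compound is compound 4 `COc1cc(NC(C)CCCNC(=O)Nc2ccc(C(F)(F)F)cc2)c2ncccc2c1`, which has trifluoromethyl in place of bromo on an aromatic carbon, para to a large group: trifluoromethyl in place of bromo on an aromatic carbon. The closest evidence is the exchange of one substituted phenyl for another in a 1.1-fold lower number from compound 1 to compound 2 (0.02 log units; within the scatter), which stayed within the scatter. The larger steps, a 5.7-fold higher number from compound 1 to compound 3 (0.75 log units; beyond the scatter) and a 6.0-fold higher number from compound 2 to compound 3 (0.78 log units; beyond the scatter), both introduce ((3-fluorophenyl)carbamoyl)amino, a much bigger change than the one considered here, so they bear on it only weakly. For the measured compounds named here, no measured compound carries trifluoromethyl. No step beyond the scatter is therefore expected in this assay. The expected step is a 1.1-fold lower number from compound 2 to compound 4 (0.05 log units; within the scatter). The estimate for compound 4 is 16000 nM, with an expected range of 7000 nM to 35000 nM.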

Compound 4, half-maximal inhibitory concentration: 7400 nM
Estimate against measurement, compound 4: 2.2-fold (0.33 log units) above, within the range that was stated.
By their numbers in this assay, from the lowest: compound 4; then compounds 2 and 1 (each within the scatter of the next); then compound 3.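

In this assay, the exchange on an aromatic carbon para to a large group is not silent: trifluoromethyl in place of bromo gives a 2.4-fold lower number from compound 2 to compound 4 (0.39 log units; beyond the scatter), whereas the earlier exchange of one substituted phenyl for another gave only a 1.1-fold lower number from compound 1 to compound 2 (0.02 log units; within the scatter). The 4-(trifluoromethyl)phenyl group also separates from 3-fluorophenyl, with a 2.6-fold lower number from compound 1 to compound 4 (0.41 log units; beyond the scatter), and the widest step in the set is a 15-fold lower number from compound 3 to compound 4 (1.16 log units; beyond the scatter), so compound 4 now holds the low end of the series on its own. No measurement available here bears on why trifluoromethyl differs from bromo at this place.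

On these data alone, whether a nitrile or a methyl group on the same aromatic carbon would fall with compound 4 or with compound 2 remains open. Also open, as far as these compounds go, is whether an amine or a carboxylic acid there would keep the lower number.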